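From Chlorine to Fluorine on the Aryl Ketone

The source may hold more compounds than are shown below. What is called first, only, known or untested is meant among the compounds shown, and "the series" means these compounds.

Of the compounds shown here, three sharing one core have been tested in a functional assay on the whole organism (Ear) for inhibition, with Mus musculus as the target, with a stated time of 30 min, at a dose of 100 mg/kg by the intraperitoneal route; a lower number here means less inhibition, a higher number more inhibition at the dose given (going by the name of the read-out). Compound 1 `N=C(N)N/N=C/c1ccc(/C=C/C(=O)c2cccc(Br)c2)cc1` gives 49.7%. Compound 2 `N=C(N)N/N=C/c1ccc(/C=C/C(=O)c2ccc(Br)cc2)cc1` gives 68.9%. Compound 3 `N=C(N)N/N=C/c1ccc(/C=C/C(=O)c2ccc(Cl)cc2)cc1` gives 56.4%, which places compound 3 second highest of the three, within the scatter of compound 1 and beyond the scatter below compound 2. The step of a number 12.5 percentage points lower from compound 2 to compound 3 (beyond the scatter) bears most directly on the next change, since it also swaps one halogen for another on the same aromatic carbon. Compound 4 `N=C(N)N/N=C/c1ccc(/C=C/C(=O)c2ccc(F)cc2)cc1` differs from compound 3 by fluoro in place of chloro on an aromatic carbon. The earlier halogen swap lowered the read-out modestly, and the same kind of swap again, now to fluoro, is expected to lower it once more by a modest amount, so the estimated step is a number 8.4 percentage points lower from compound 3 to compound 4 (within the scatter). Compound 4 is therefore expected to give about 48%, with a range from 33% to 63%. Going by the values given here, only one measured step speaks to this change, so the range is kept wide.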

Compound 4, a percentage reported as inhibition, in the whole organism at one dose (the size of the read-out at that dose, not a potency): 90.7%
The estimate for compound 4 lay 42.7 percentage points below the measured number, outside the stated range (above it).
By their numbers in this assay, from the lowest: compounds 1 and 3 (each within the scatter of the next); then compound 2; then compound 4.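

In this assay, fluoro in place of chloro at this position, para to a large group, gives a number 34.3 percentage points higher from compound 3 to compound 4 (beyond the scatter), and fluoro in place of bromo gives a number 21.8 percentage points higher from compound 2 to compound 4 (beyond the scatter). The three halogens at this position therefore do not fall in a simple line: chloro gives the lowest number of the three, with bromo above it and fluoro highest, and the change from the 3-bromophenyl group to the 4-fluorophenyl group gives a number 41 percentage points higher from compound 1 to compound 4 (beyond the scatter). Nothing available explains why fluoro stands out here.

Whether a halogen is needed at all remains open, as a plain phenyl ring and a methoxy or nitrile group at this position are not among the compounds shown. From the compounds shown here alone, each number in this assay also comes from a single dose, so how these compounds compare at other doses is unknown.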